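The source may hold more compounds than are shown below. What is called first, only, known or untested is meant among the compounds shown, and "the series" means these compounds.

- Compound 1 `COc1ccccc1/C=C(/SCc1ccc(Cl)cc1)C(=O)c1ccc([N+](=O)[O-])cc1`: 10000 nM
- Compound 2 `COc1ccccc1/C=C(/SCc1ccc(Cl)cc1)C(=O)c1ccc(Cl)cc1`: 1000 nM

In a functional assay on DU-145 cells (Homo sapiens) for inhibition, read by trypan blue exclusion, with a stated time of 96 h (a lower number here means a stronger inhibitor of growth, a higher number a weaker inhibitor of growth), compound 1 gives 10000 nM, the higher of the two numbers. Compound 3 `CN(C)c1ccc(/C=C(/SCc2ccc(Cl)cc2)C(=O)c2ccc([N+](=O)[O-])cc2)cc1` has not yet been measured. It carries 4-(dimethylamino)phenyl in place of 2-methoxyphenyl on a double-bonded chain carbon bound to a double-bonded chain carbon. Within the data shown here, the only measured step, a 10-fold lower number from compound 1 to compound 2 (1.00 log units; beyond the scatter), swaps a different group, so it shows only how large a single change on the shared core can be. Among the measured compounds shown here, no measured step covers this swap, and the direction is a loose guess. A modest move to a lower number is expected, estimated as a 3.3-fold lower number from compound 1 to compound 3 (0.52 log units; beyond the scatter). Compound 3 is expected at 3000 nM, with an estimated range of 500 nM to 15000 nM.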

Compound 3, concentration for 50% growth inhibition: > 100000 nM
Compound 3: a limit, no number (the forecaster's own chance of this, stated with the estimate: 10%); middle value at least 33-fold (1.52 log units) from the limit.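

In this assay, putting 4-(dimethylamino)phenyl in place of 2-methoxyphenyl gives an at least 10-fold higher number from compound 1 to compound 3 (1.00 log units; beyond the scatter). This shows that the group on the double-bonded chain carbon can also change growth inhibition, and that this swap makes the compound a weaker inhibitor, a direction the earlier step did not show. For compound 3 the result is a limit of the assay and not a number, so the full size of the step stays unknown: the limit of > 100000 nM in this assay, at which 1 of the 3 values shown sits.

As far as these compounds go, the two groups differ in more than one way, so it remains open whether 4-methoxyphenyl would behave like 2-methoxyphenyl or like 4-(dimethylamino)phenyl. From the compounds shown here alone, it is also open whether this swap has the same result when chloro stands in place of nitro.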